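The source may report more compounds than this note shows. Statements on the series, on what has been measured and on what is new or still open speak of the compounds shown alone.

Compound 1, `O=C(CCCCC1CCSS1)NCc1cn(CCCOc2ccc3cc(-c4ccc(Br)cc4)c(=O)oc3c2)nn1`: 69.1%. Compound 2, `CC(=O)c1cc2ccc(OCCCCCn3cc(CNC(=O)CCCCC4CCSS4)nn3)cc2oc1=O`: 20.7%.

In a functional assay on PC-12 cells (Rattus norvegicus) for cytotoxicity, read by MTT assay, with stated times of 3 h and 2 h, tested at 20 uM (on this read-out higher numbers stand for a stronger effect at the one concentration tested and lower numbers for a weaker effect), compound 1 gives 69.1%, while compound 2 gives 20.7%, the lowest of the two numbers and beyond the scatter from compound 1. Compound 3, `O=C(CCCCC1CCSS1)NCc1cn(CCCCCOc2ccc3cc(-c4ccc(Br)cc4)c(=O)oc3c2)nn1`, has not yet been measured. Compared with compound 2 it carries 4-bromophenyl in place of acetyl on an aromatic carbon. For the measured compounds named here, no step between measured compounds covers this change. Compound 3 is nevertheless expected to rise well beyond the scatter, a step of a number 39.3 percentage points higher from compound 2 to compound 3 (beyond the scatter), because compound 1 with its 4-bromophenyl group gives 69.1%. Compound 3 is estimated at 60%, within 40% to 78%.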

Compound 3, a percentage reported as activity, at one concentration (the size of the read-out at that concentration, not a potency): 52.3%
Beside the measured number, compound 3's estimate is 7.7 percentage points above it; the range from low to high includes it.
By their numbers in this assay, from the lowest: compound 2; then compound 3; then compound 1.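

The exchange of acetyl for 4-bromophenyl on this aromatic carbon, two atoms from the ring oxygen, gives in this assay a number 31.6 percentage points higher from compound 2 to compound 3 (beyond the scatter) with the rest of the structure unchanged. For the compounds shown here, compound 1 and compound 2 differed in more than this one place, so only this pair ties the rise to the group alone. Nothing available explains why this group raises the read-out. As far as these compounds go, it remains open whether the bromine is needed, as plain phenyl would show, and how an amine or a carboxylic acid would behave on this carbon.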